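This account rests on a few compounds, and the source may have more. Where it says the series, first, only, none or still open, it means among the compounds named here.

Of the compounds shown here, three built on a shared core have been measured in a physicochemical assay for solubility, with a stated time of 18 h, at pH 7.4; on this read-out lower numbers stand for lower solubility and higher numbers for higher solubility. Compound 1 `FC(F)(F)c1ccc(-c2ccc3c(NCCCNCc4ccco4)ccnc3c2)cc1` gives 32000 nM, compound 2 `Clc1ccc(Oc2ccc3c(NCCCNCc4ccco4)ccnc3c2)cc1` gives 14500 nM, and compound 3 `c1coc(CNCCCNc2ccnc3cc(C4CCCCC4)ccc23)c1` gives 4200 nM. Compound 2 therefore stands second of the three: the step from compound 1 to compound 2 is a 2.2-fold lower number from compound 1 to compound 2 (0.34 log units; beyond the scatter), and the step from compound 2 to compound 3 is a 3.5-fold lower number from compound 2 to compound 3 (0.54 log units; beyond the scatter), while the step from compound 1 to compound 3 is a 7.6-fold lower number from compound 1 to compound 3 (0.88 log units; beyond the scatter). All three of these steps change the group on an aromatic carbon of the core.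

Compound 4 `COc1cccc(CNCCCNc2ccnc3cc(Oc4ccc(Cl)cc4)ccc23)c1O` is not yet measured. Compared with compound 2 it differs elsewhere, at the other end of the molecule: 2-hydroxy-3-methoxyphenyl in place of furan-2-yl on a saturated chain carbon bound to an amine nitrogen. Within the data shown here, none of the measured steps touches this position, so nothing measured bears directly on it, and the expectation must rest on the value of compound 2 alone, with a wide range. Because compound 2 gives 14500 nM, compound 4 is estimated to change by a 1.5-fold lower number from compound 2 to compound 4 (0.16 log units; within the scatter) in this assay, a step that may well stay within the scatter. The estimate for compound 4 is 10000 nM, with a range from 3000 nM to 40000 nM.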

Compound 4, solubility: 14500 nM
Compound 4: middle estimate off by 1.5-fold (0.16 log units), on the low side; measured number inside the range.
By their numbers in this assay, from the lowest: compound 3; then compounds 2 and 4 (each within the scatter of the next); then compound 1.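

At this end of the molecule, 2-hydroxy-3-methoxyphenyl in place of furan-2-yl gives no change at the digits printed from compound 2 to compound 4 (within the scatter) in this assay, even though the entering group has 9 heavy atoms against 5, a six-membered aromatic ring of carbon only, and 1 hydrogen-bond donor where the furan-2-yl has none. The earlier steps shown here all changed the group on an aromatic carbon of the shared core, and each was beyond the scatter, as with a 7.6-fold lower number from compound 1 to compound 3 (0.88 log units; beyond the scatter); this first step on a saturated chain carbon bound to an amine nitrogen is the only one of the set within it. Nothing available explains why the number holds here, so this remains an observation on a single pair.

A single pair cannot show whether the same swap would leave the number in place with 4-(trifluoromethyl)phenyl or cyclohexyl on the core, as in compound 1 and compound 3. It also leaves open how this position would respond to a carboxylic acid, a second amine or a longer chain.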